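Series notes: acetylsulfamoyl in place of hydrogen

The compounds below may be only part of what the source reports. "The series", "measured", "known", "first", "only" and "open" are said of these compounds alone.

Measured so far:
compound 1 `Oc1ccc(O)c(-c2cc(-c3ccccc3)nn2-c2ccccc2)c1` — 16700 nM
compound 2 `Oc1ccc(O)c(-c2cc(-c3ccc(Cl)cc3)nn2-c2ccccc2)c1` — 14600 nM

In a functional assay on cells (Cancer cell lines, Homo sapiens) for cytotoxicity, read by sulforhodamine B assay, with a stated time of 48 h (on this read-out higher numbers stand for weaker inhibition of growth and lower numbers for stronger inhibition of growth), compound 1 gives 16700 nM, the highest of the two numbers. Compound 2 gives 14600 nM; the step of a 1.1-fold lower number from compound 1 to compound 2 (0.06 log units; within the scatter) stays within the scatter. Compound 3 `CC(=O)NS(=O)(=O)c1ccc(-n2nc(-c3ccccc3)cc2-c2cc(O)ccc2O)cc1` differs from compound 1 by acetylsulfamoyl in place of hydrogen on an aromatic carbon. For the measured compounds named here, no measured step touches that position, and the only step known, a 1.1-fold lower number from compound 1 to compound 2 (0.06 log units; within the scatter), changed nothing beyond the scatter. For compound 3 in this assay no step beyond the scatter is expected, a 1.1-fold lower number from compound 1 to compound 3 (0.05 log units; within the scatter). Compound 3 is therefore estimated at 15000 nM, within 6000 nM to 40000 nM.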

Compound 3, concentration for 50% growth inhibition: 100000 nM
Beside the measured number, compound 3's estimate is 6.7-fold (0.82 log units) below it, and the stated range ends below it.
By their numbers in this assay, from the lowest: compounds 2 and 1 (each within the scatter of the next); then compound 3.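

In this assay, acetylsulfamoyl in place of hydrogen on this aromatic carbon gives a 6.0-fold higher number from compound 1 to compound 3 (0.78 log units; beyond the scatter). This position, untouched by the chloro change, therefore responds to substitution, and this change moves toward weaker inhibition of growth. Nothing available accounts for the shift.

Among the compounds shown, only one group sits at this position, so it stays open whether the shift belongs to acetylsulfamoyl alone or to substitution here in general. An amine, a carboxylic acid or plain sulfamoyl at the same carbon would separate these cases.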